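A few compounds are considered here, and "the series" means these few. Any claim that something is new, unique, unknown or untested is made for them only; others in the source may bear on it.

Measured compounds:
Compound 1 `COc1ccc(-c2nnc(SCC(=O)Nc3ccc(/C(C)=N/O)cc3)n2-c2ccccc2)cc1` gives 56% in a functional assay on the whole organism (strain albino) for inhibition, with Rattus norvegicus as the target, read by paw edema, with stated times of 30 min and 2 h, at a dose of 0.28 mmol/kg by the oral route; on this read-out lower numbers stand for less inhibition and higher numbers for more inhibition at the one dose given (going by the name of the read-out).
Compound 2 `CCn1c(SCC(=O)Nc2ccc(C(C)=O)cc2)nnc1-c1ccc(OC)c(OC)c1` gives 59% in this assay.
Compound 3 `COc1ccc(-c2nnc(SCC(=O)Nc3ccc(/C(C)=N/O)cc3)n2-c2ccccc2)cc1OC` gives 63% in this assay.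

Compound 3 differs from compound 1 by methoxy in place of hydrogen on an aromatic carbon. That change made a step of a number 7 percentage points higher from compound 1 to compound 3 (within the scatter). Compound 1 and compound 2 carry different cores; the difference between the two cores is not broken down here, and their values in this assay lie close together.

Compound 4 `CCn1c(SCC(=O)Nc2ccc(C(C)=O)cc2)nnc1-c1cc(OC)c(OC)c(OC)c1` is not yet measured. It differs from compound 2 by methoxy in place of hydrogen on an aromatic carbon. The place is not the same as in compound 3: here it is also meta to a methoxy group (2 heavy atoms), so this is the same kind of change, not the same. Beside the earlier step, the expected step is a number 5 percentage points higher from compound 2 to compound 4 (within the scatter), because the earlier step of a number 7 percentage points higher from compound 1 to compound 3 (within the scatter) stayed within the scatter and nothing in the series shows this change doing more. Compound 4 is therefore expected to give about 64% in this assay, estimated to fall between 52% and 76%. The expectation rests on compound 2 at 59% and on the step of a number 7 percentage points higher from compound 1 to compound 3 (within the scatter).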

Compound 4, a percentage reported as inhibition, in the whole organism at one dose (the size of the read-out at that dose, not a potency): 50%
Compound 4: middle estimate off by 14 percentage points, on the high side; the whole stated range lies above it.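

In this assay, the added methoxy gave a number 9 percentage points lower from compound 2 to compound 4 (within the scatter), and neither this step nor the earlier one stands clear of the scatter on its own. Set side by side, however, the two steps do not agree, so in this series the change cannot be carried from one core to another as a fixed increment: the same change on two cores in this assay, a number 7 percentage points higher (within the scatter) from compound 1 to compound 3 and a number 9 percentage points lower (within the scatter) from compound 2 to compound 4, 16 percentage points apart, beyond the scatter of two such steps This does not show which difference between the two pairs matters, the core or the place of the new methoxy, which in compound 4 is ortho to a methoxy group and meta to a methoxy group; the two differences go together here, and each step rests on a single pair.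

Still open, going by these compounds, is what the same change does on the core of compound 1 when placed as in compound 4, which would separate core from place. Also open, on these data alone, is how an amine or a carboxylic acid would behave in that place on either core.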